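The source may report more compounds than this note shows. Statements on the series, on what has been measured and on what is new or still open speak of the compounds shown alone.

Measured in an ADME assay on S9 fraction from liver (Rattus norvegicus) for metabolic stability, read by LC-MS, using NADPH, with a stated time of 30 min; a lower number here means that less of the compound is left, a higher number that more of the compound is left:

- Compound 1 `CCCCCCCCc1ccc(OCC(=O)Cn2nnc(SC)n2)cc1`: < 5%, a limit of the assay
- Compound 2 `CCCCCCCCc1ccc(OCC(=O)Cn2nnc(C(=O)O)n2)cc1`: 52%
- Compound 3 `CCCCCCCCc1ccc(OCC(=O)Cn2nnc(-c3ccc(C(=O)O)cc3)n2)cc1`: < 5%, a limit of the assay

Compound 2 is the only one of the three with an actual number, 52%. The other two share a single bound: the limit of < 5% in this assay, at which 2 of the 3 values shown sit.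

Compound 4 `CCCCCCCCc1ccc(OCC(=O)Cn2nnnc2SC)cc1` has 5-(methylsulfanyl)-1H-tetrazol-1-yl in place of 5-carboxy-2H-tetrazol-2-yl on a saturated chain carbon bound to a carbonyl carbon.

Among the compounds with values here, two measured steps bear on this change. Carboxy in place of methylsulfanyl gave a number at least 47 percentage points higher from compound 1 to compound 2 (beyond the scatter), a large step. Replacing carboxy with 4-carboxyphenyl gave a number at least 47 percentage points lower from compound 2 to compound 3 (beyond the scatter), also large. The remaining step cannot be sized: a step that the two limits leave unreadable from compound 1 to compound 3. None of these steps tests the move from the 2H-tetrazol-2-yl to the 1H-tetrazol-1-yl attachment, so that part of the change remains unmeasured.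

Compound 4 gives up the carboxy and carries methylsulfanyl instead, so the step from compound 1 to compound 2, read in reverse, points to a large fall in this assay. The expected step is a number 45 percentage points lower from compound 2 to compound 4 (beyond the scatter). For compound 4 the estimate is 7%, with an expected range from 2% to 22%.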

Compound 4, percent of the compound remaining: 21%
For compound 4 the middle estimate is 14 percentage points below the measured one; measured number inside the range.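

With the methylsulfanyl group held fixed, compound 4 separates the attachment of the tetrazole from its substituent: in this assay, 5-(methylsulfanyl)-1H-tetrazol-1-yl in place of 5-(methylsulfanyl)-2H-tetrazol-2-yl on a saturated chain carbon bound to a carbonyl carbon gives a number at least 16 percentage points higher from compound 1 to compound 4 (beyond the scatter). This step is a bound and not a full size, since compound 1 stands only at a limit of the assay: the limit of < 5% in this assay, at which 2 of the 4 values shown sit. The attachment therefore counts at this position in its own right, yet the change from the carboxy compound, which alters both attachment and substituent, still gives a number 31 percentage points lower from compound 2 to compound 4 (beyond the scatter).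

The compounds shown leave open how a carboxylic acid on the 1H-tetrazol-1-yl attachment would read in this assay, and so how much of that last step belongs to each of the two alterations. They also leave open whether an amine or a methoxy group in place of methylsulfanyl on the 1H-tetrazol-1-yl attachment would read like compound 4.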